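Adding a Methyl to the Ring on the Sulfonyl Sulfur

The source may hold more compounds than are shown below. What is called first, only, known or untested is meant among the compounds shown, and "the series" means these compounds.

Compound 1 `O=C(NCc1ccc(S(=O)(=O)c2cc(F)cc(F)c2)cc1)c1cc2cnccc2[nH]1` gives 63%.
Compound 2 `O=C(NCc1ccc(S(=O)(=O)c2ccc(F)cc2)cc1)c1cc2cnccc2[nH]1` gives 72%.
Compound 3 `O=C(NCc1ccc(S(=O)(=O)c2ccccc2)cc1)c1cc2cnccc2[nH]1` gives 54%.

Three compounds share one core and differ only in the ring on the sulfonyl sulfur. In an ADME assay on microsomes from liver (Mus musculus) for metabolic stability, read by LC-MS, with a stated time of 30 min, tested at 1 uM (on this read-out lower numbers stand for a less stable compound and higher numbers for a more stable compound), compound 3 stands lowest of the three numbers: the step of a number 18 percentage points lower from compound 2 to compound 3 (beyond the scatter) lies beyond the scatter, while the step of a number 9 percentage points lower from compound 1 to compound 3 (within the scatter) lies within it. Compound 4 `Cc1ccccc1S(=O)(=O)c1ccc(CNC(=O)c2cc3cnccc3[nH]2)cc1` carries methyl in place of hydrogen on an aromatic carbon. Going by the values given here, no measured step adds a methyl to this ring; the nearest comparison is the step of a number 18 percentage points lower from compound 2 to compound 3 (beyond the scatter), which changes a different group on the same ring. A methyl is not a fluoro, so its direction cannot be read from that step, and the step of a number 2 percentage points lower from compound 3 to compound 4 (within the scatter) is expected to stay small. Compound 4 is therefore estimated at 52%, within a range from 32% to 72%.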

Compound 4, percent of the compound remaining: 15%
Estimate against measurement, compound 4: 37 percentage points above, and the stated range ends above it.
By their numbers in this assay, from the lowest: compound 4; then compounds 3, 1 and 2 (each within the scatter of the next, the first and the last beyond it).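

In this assay, going by these compounds alone, this ring proves far more sensitive than the fluoro changes suggested: one methyl on an aromatic carbon, ortho to a large group, gives a number 39 percentage points lower from compound 3 to compound 4 (beyond the scatter), a larger step than any among the earlier compounds. The 2-methylphenyl ring also falls well short of both fluorinated rings, with a number 57 percentage points lower from compound 2 to compound 4 (beyond the scatter) and a number 48 percentage points lower from compound 1 to compound 4 (beyond the scatter). No measurement at hand explains this drop. As far as these compounds go, whether a chloro or a methoxy in the same place would cost as much stays open, as does whether the loss belongs to the methyl itself or to its place on the ring.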